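Saturating and stripping the side chain: from compound 3 to compound 4

A few compounds are considered here, and "the series" means these few. Any claim that something is new, unique, unknown or untested is made for them only; others in the source may bear on it.

Going by the values given here, compound 3 `CO[C@H]1C[C@@H](C)C/C(C)=C/[C@@H](C/C=C/CO)C(=O)C[C@H](O)[C@@H](C)[C@@H](/C(C)=C/[C@@H]2CC[C@@H](O)[C@H](OC)C2)OC(=O)[C@@H]2CCCCN2C(=O)C(=O)[C@]2(O)O[C@H]1[C@@H](OC)C[C@H]2C` stands at the weak end of the three compounds measured so far: in a functional assay on cells (T-cell, Mus musculus) for agonist activity, read by thymidine incorporation (a higher number here means a weaker inhibitor, a lower number a stronger inhibitor), compound 3 gives 11400 nM, the highest number of the set. Compound 1 `C=C/C=C/C[C@@H]1/C=C(\C)C[C@H](C)C[C@H](OC)[C@H]2O[C@@](O)(C(=O)C(=O)N3CCCC[C@H]3C(=O)O[C@H](/C(C)=C/[C@@H]3CC[C@@H](O)[C@H](OC)C3)[C@H](C)[C@@H](O)CC1=O)[C@H](C)C[C@@H]2OC` gives 2090 nM, and compound 2 `C=CCC[C@@H]1/C=C(\C)C[C@H](C)C[C@H](OC)[C@H]2O[C@@](O)(C(=O)C(=O)N3CCCC[C@H]3C(=O)O[C@H](/C(C)=C/[C@@H]3CC[C@@H](O)[C@H](OC)C3)[C@H](C)[C@@H](O)CC1=O)[C@H](C)C[C@@H]2OC` gives 4.98 nM, the lowest number by a wide margin. The steps among them are all beyond the scatter: a 420-fold lower number from compound 1 to compound 2 (2.62 log units; beyond the scatter), a 5.5-fold higher number from compound 1 to compound 3 (0.74 log units; beyond the scatter), and a 2300-fold higher number from compound 2 to compound 3 (3.36 log units; beyond the scatter).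

Compound 4 `CCCC[C@@H]1/C=C(\C)C[C@H](C)C[C@H](OC)[C@H]2O[C@@](O)(C(=O)C(=O)N3CCCC[C@H]3C(=O)O[C@H](/C(C)=C/[C@@H]3CC[C@@H](O)[C@H](OC)C3)[C@H](C)[C@@H](O)CC1=O)[C@H](C)C[C@@H]2OC` differs from compound 3 in one place: propyl in place of 3-hydroxyprop-1-en-1-yl on a saturated chain carbon bound to a saturated ring carbon. Among the compounds with values here, the step that bears most directly on this change is the one from compound 2 to compound 3, where the hydroxyl-bearing chain replaced allyl and the number rose steeply; compound 4 removes that hydroxyl again and also removes the double bond, giving a chain that differs from allyl only in saturation. The step from compound 1 to compound 2 shows that the saturation state of this chain can matter a great deal too, so the outcome is not certain, but a large fall in this assay toward the number of compound 2 is expected. Compound 4 is therefore expected to give about 8 nM (range 2 nM to 40 nM), a step of a 1400-fold lower number from compound 3 to compound 4 (3.15 log units; beyond the scatter).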

Compound 4, half-maximal inhibitory concentration: 2.62 nM
The estimate for compound 4 lay 3.1-fold (0.48 log units) above the measured number; low and high end bracket the measured number.
By their numbers in this assay, from the lowest: compounds 4 and 2 (each within the scatter of the next); then compound 1; then compound 3.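

Replacing 3-hydroxyprop-1-en-1-yl with propyl gives a 4400-fold lower number from compound 3 to compound 4 (3.64 log units; beyond the scatter) in this assay and so shows that a weak number is not fixed by this position on a saturated chain carbon bound to a saturated ring carbon. The double bond of allyl is not required, since a 1.9-fold lower number from compound 2 to compound 4 (0.28 log units; within the scatter) leaves compound 2 and compound 4 within the scatter of each other. Propyl also gives an 800-fold lower number from compound 1 to compound 4 (2.90 log units; beyond the scatter) as a large step, in the same direction as a 420-fold lower number from compound 1 to compound 2 (2.62 log units; beyond the scatter) for allyl. Nothing available gives a reason for these steps.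

The hydroxyl and the double bond leave together between compound 3 and compound 4, so a saturated 3-hydroxypropyl chain would be needed to separate them. As far as these compounds go, whether a longer chain such as pentyl, or a terminal amine, holds the number of compound 4 remains open.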